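Methoxy on the pendant ring of a chromanone series

The source may report more compounds than this note shows. Statements on the series, on what has been measured and on what is new or still open speak of the compounds shown alone.

Three compounds share a core and have been run in an in vitro assay on BTI-TN-5B1-4 cells for inhibition of Amine oxidase [flavin-containing] B (Homo sapiens); on this read-out lower numbers stand for stronger inhibition and higher numbers for weaker inhibition. Compound 1 `O=C1C[C@H](c2ccc(F)cc2)Oc2cc(F)ccc21` gives 150 nM. Compound 2 `COc1ccc(C2CC(=O)c3ccc(C)cc3O2)cc1` gives 3350 nM. Compound 3 `COc1ccc2c(c1)OC(c1ccccc1)CC2=O` gives 1470 nM, which places it second highest of the three numbers: its nearest neighbour is compound 2, whose number is higher by a margin beyond the scatter, and its furthest neighbour is compound 1, whose number is lower by a margin well beyond the scatter. No pair among these three differs in only one place, so no single-point step can be read from them.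

Compound 4 `COc1ccc(C2CC(=O)c3ccc(OC)cc3O2)cc1` is not yet measured in this assay. It differs from compound 3 in one place: methoxy in place of hydrogen on an aromatic carbon, para to a large group. Compound 2 also carries a methoxy on its pendant ring, but it differs from compound 3 in a second place as well, so its number can only be noted, not ascribed to the methoxy. With nothing more to go on, the expected step from compound 3 to compound 4 is small, a 1.4-fold higher number from compound 3 to compound 4 (0.13 log units; within the scatter), likely within the scatter and, if anything, towards a higher number. Compound 4 is therefore expected to give about 2000 nM in this assay, with a range from 700 nM to 6000 nM.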

Compound 4, half-maximal inhibitory concentration: 7180 nM
For compound 4 the middle estimate is 3.6-fold (0.56 log units) below the measured one, and the stated range ends below it.
By their numbers in this assay, from the lowest: compound 1; then compound 3; then compound 2; then compound 4.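

In this assay, methoxy in place of hydrogen on an aromatic carbon, para to a large group, gives a 4.9-fold higher number from compound 3 to compound 4 (0.69 log units; beyond the scatter), so this position does respond to the change, and the response is towards weaker inhibition, a modest step but one beyond the scatter. The second pair adds a different change at a different place, with methoxy in place of methyl on an aromatic carbon giving a 2.1-fold higher number from compound 2 to compound 4 (0.33 log units; beyond the scatter), again modest and beyond the scatter and again towards weaker inhibition, so on these two pairs alone neither methoxy change improves the number. No measurement here bears on why either step takes this direction or size.

As far as these compounds go, whether the loss at the para position belongs to methoxy specifically remains open, since a hydroxyl, an ethoxy or an amine on the same carbon would be needed to separate the group from the mere presence of a substituent. Compound 1 stands apart at 150 nM and differs from the others in more than one place, so steps to it cannot be read, and what its fluorines contribute is also unresolved.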